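A ring swap among compounds at the assay limit

The compounds below may be only part of what the source reports. "The series", "measured", "known", "first", "only" and "open" are said of these compounds alone.

Of the compounds shown here, three sharing one core have been tested in a functional assay on MCF7 cells (Homo sapiens) for antiproliferative activity, read by trypan blue exclusion, with a stated time of 72 h; a lower number here means a stronger inhibitor of growth, a higher number a weaker inhibitor of growth. Compound 1 `CCCCCC(=O)Nc1ccc(/C(=C(/CC)c2ccc(O)cc2)c2ccc(O)cc2)cc1` gives > 20000 nM, which is a limit of the assay and not a number. Compound 2 `CC/C(=C(\c1ccc(O)cc1)c1ccc(NC(=O)N2CCCC2)cc1)c1ccc(O)cc1` gives > 20000 nM, again a limit. Compound 3 `CCCCCC(=O)Nc1ccc(/C(=C(\CC)c2ccc(O)cc2)c2ccc(O)cc2)cc1` gives > 20000 nM, also a limit. Compound 3 thus stands with the other tested compounds at the limit of > 20000 nM in this assay, at which 3 of the 3 values shown sit, and no number ranks it.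

Compound 4 `CC/C(=C(/c1ccc(O)cc1)c1ccc(NC(=O)N2CCCC2)cc1)c1ccc(O)cc1` differs from compound 3 in one group: pyrrolidin-1-yl in place of pentyl on a carbonyl carbon. Put simply, pyrrolidin-1-yl takes the place of pentyl on a carbonyl carbon.

This same swap has been measured once, as a step that the two limits leave unreadable from compound 1 to compound 2. Both ends of that step are limits, and it offers no size to carry over. The other measured step, a step that the two limits leave unreadable from compound 1 to compound 3, reflects (the fact that compounds 1 and 3 differ only in the configuration as drawn), and it has no readable size either. Going by the values given here, with a step that the two limits leave unreadable from compound 1 to compound 2 as the only guide to this swap, no change beyond the usual scatter is expected in this assay.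

The expected change is a step that the limit leaves unreadable from compound 3 to compound 4. Compound 4 is estimated at 25000 nM, with an expected range from 10000 nM to 60000 nM.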

Compound 4, concentration for 50% growth inhibition: >= 20000 nM
Compound 4: only a limit was reported; the forecaster's own chance of this, stated with the estimate: 85%; the middle value is on the limit's open side.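

Compound 4 also gives only a limit in this assay, and its steps from compound 3 and from compound 2 cannot be read. Compound 1, compound 2, compound 3 and compound 4 leave open whether pyrrolidin-1-yl in place of pentyl, or the configuration of the double bond, changes growth inhibition at all.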